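From pyrrolidin-1-yl to piperidin-1-yl at an assay limit

The source may hold more compounds than are shown below. What is called first, only, known or untested is meant among the compounds shown, and "the series" means these compounds.

Compound 1 (`CCCCCCCCOP(=O)(O)OCCSC(=S)N1CCCCC1`) gives > 100000 nM in a functional assay on PC-3 cells (Homo sapiens) for inhibition, read by MTT assay, with stated times of 18 h and 4 h (a higher number here means a weaker inhibitor, a lower number a stronger inhibitor), and this is a limit of the assay, not a number. Compound 2 (`CCCCCCOP(=O)(O)OCCSC(=S)N1CCCCCC1`) gives > 100000 nM in this assay and this too is a limit. Compound 3 (`CCCCCCOP(=O)(O)OCCSC(=S)N1CCCC1`) stands at > 100000 nM as a limit as well, so it has no numeric place in the series. The change to compound 4 (`CCCCCCOP(=O)(O)OCCSC(=S)N1CCCCC1`) is piperidin-1-yl in place of pyrrolidin-1-yl on a thiocarbonyl carbon and it puts piperidin-1-yl in place of pyrrolidin-1-yl on a thiocarbonyl carbon. Going by the values given here, the one measured step that bears on this change is a step that the two limits leave unreadable from compound 2 to compound 3 and it offers no size to carry over. Among the compounds with values here, the only other guide is the limit of > 100000 nM in this assay, at which 3 of the 3 values shown sit, and no compound here has yet given a number. No shift beyond the scatter is therefore expected in this assay in either direction. The estimated step that the limit leaves unreadable from compound 3 to compound 4 is expected to have no readable size. Compound 4 is estimated at 150000 nM with an expected range from 70000 nM to 300000 nM and the assay will most likely report only a limit.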

Compound 4, half-maximal inhibitory concentration: > 100000 nM
Compound 4 was reported as a limit (the forecaster's own chance of this, stated with the estimate: 90%); the middle value lies beyond the limit too.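

Compound 1, compound 2, compound 3 and compound 4 all stand only at a limit in this assay, and the steps among them cannot be read: the limit of > 100000 nM in this assay, at which 4 of the 4 values shown sit.

The compounds shown leave open whether changing the ring on the thiocarbonyl carbon or the saturated chain alters inhibition at all.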